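The compounds below may be only part of what the source reports. "The series", "measured", "known", "first", "only" and "open" are said of these compounds alone.

Compound 1 `Nc1nc(N)c(CCCN(Cc2ccc(NC(CCC(=O)O)C(=O)O)cc2)c2cc(F)c(F)cc2[N+](=O)[O-])c(O)n1`: > 100000 nM
Compound 2 `CC(C)(C)OC(=O)CCC(Nc1ccc(CN(CCCc2c(N)nc(N)nc2O)c2cc(F)cc(F)c2[N+](=O)[O-])cc1)C(=O)OC(C)(C)C`: 17000 nM

Of the compounds shown here, two have so far been tested in a functional assay on CCRF-CEM cells (Homo sapiens) for cytotoxicity, in the absence of a further agent; a higher number here means a weaker inhibitor, a lower number a stronger inhibitor. Compound 1 is reported only as a limit, > 100000 nM, and not as a number. Among the measured compounds shown here, compound 2, at 17000 nM, therefore holds the only actual number in the set, and nothing else yet shows how it ranks on a numerical scale.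

The next compound to be tested is compound 3 `CC(C)(C)OC(=O)CCC(Nc1ccc(CN(CCCc2c(N)nc(N)nc2O)c2ccc([N+](=O)[O-])c(F)c2F)cc1)C(=O)OC(C)(C)C`, which has the same atoms as compound 2, joined differently: 2,3-difluoro-4-nitrophenyl in place of 3,5-difluoro-2-nitrophenyl on an amine nitrogen. A 2,3-difluoro-4-nitrophenyl stands in place of the 3,5-difluoro-2-nitrophenyl on an amine nitrogen, and the rest of the molecule is unchanged.

For the measured compounds named here, no measured pair in the set isolates a change of this kind, so the data offer no step from which to gauge its size. No shift beyond the usual scatter is expected, in either direction, and the expectation stays anchored on compound 2 at 17000 nM. The estimated change is a 1.1-fold lower number from compound 2 to compound 3 (0.05 log units; within the scatter). Compound 3 is expected at about 15000 nM, with an estimated range from 5000 nM to 50000 nM.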

Compound 3, half-maximal inhibitory concentration: 36000 nM
Compound 3: middle estimate off by 2.4-fold (0.38 log units), on the low side; measured number inside the range.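

Among the compounds shown here, the step on the amine nitrogen gives the first measured comparison at this position in this assay: a 2.1-fold higher number from compound 2 to compound 3 (0.33 log units; beyond the scatter). The 3,5-difluoro-2-nitrophenyl and the 2,3-difluoro-4-nitrophenyl have identical counts of heavy atoms, hydrogen-bond donors and hydrogen-bond acceptors, so rearranging the same atoms on this ring is enough to move the number modestly beyond the usual scatter, with the higher number belonging to the 2,3-difluoro-4-nitrophenyl. Both compounds give actual numbers, so this step can be read in full, unlike any comparison with the one compound reported only as a limit: the limit of > 100000 nM in this assay, at which 1 of the 3 values shown sits.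

The compounds shown leave open how the number would respond if an amine or a nitrile replaced the nitro group on this ring, or if a plain phenyl without fluorine stood on the amine nitrogen. For the compounds shown here, they also leave open whether the same rearrangement gives a step of similar size when both tert-butyl esters are replaced by carboxylic acids, since the only compound with carboxylic acids also has a different ring arrangement and is reported as a limit.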